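Replacing the methoxy group of compound 2 with hydrogen

This account rests on a few compounds, and the source may have more. Where it says the series, first, only, none or still open, it means among the compounds named here.

In a functional assay on HepG2 cells (Homo sapiens) for antiproliferative activity, read by MTT assay, with a stated time of 72 h (a lower number here means a stronger inhibitor, a higher number a weaker inhibitor), compound 1 `COc1cccc(N2C(=O)COc3ccc(-c4cnc(Cl)c(NS(=O)(=O)c5ccc(F)cc5)c4)cc32)c1` reads > 40000 nM as its result, which is a limit of the assay and not a number. In this assay, among the measured compounds shown here, compound 2 `COc1cccc(N2C(=O)COc3ccc(-c4cnc5ccccc5c4)cc32)c1` gives 2080 nM as the only actual number so far. Compound 3 `O=C1COc2ccc(-c3cnc4ccccc4c3)cc2N1c1ccccc1` has hydrogen in place of methoxy on an aromatic carbon and thus goes from 3-methoxyphenyl to phenyl. For the measured compounds named here, no measured step shows what this change does, so the expected step of a 1.2-fold higher number from compound 2 to compound 3 (0.08 log units; within the scatter) in this assay stays within the scatter, with no firm direction. Compound 3 is estimated at 2500 nM with an expected range from 800 nM to 8000 nM in this test.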

Compound 3, half-maximal inhibitory concentration: > 40000 nM
Compound 3: a limit, no number; the forecaster's own chance of this, stated with the estimate: 5%; middle value at least 16-fold (1.20 log units) away from the limit.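

Among the compounds shown here, the first measured step at this position shows that it is not indifferent to the change: going from 3-methoxyphenyl to phenyl gives an at least 19-fold higher number from compound 2 to compound 3 (1.28 log units; beyond the scatter) in this assay. Compound 3 reads as a limit of the assay and not a number. From the compounds shown here alone, the step therefore sets only a lower bound on the loss, and its full size stays unknown: the limit of > 40000 nM in this assay, at which 2 of the 3 values shown sit.

The compounds shown leave open whether methoxy itself matters here, or whether a hydroxyl group, a fluorine atom or a longer ethoxy chain on the same aromatic carbon would keep a measurable number.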